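The source may report more compounds than this note shows. Statements on the series, on what has been measured and on what is new or still open speak of the compounds shown alone.

Compound 2 `CS(=O)(=O)c1ccc(N2N=C(c3ccc(Cl)cc3)CCC2=O)cc1` carries a 4-chlorophenyl group, and in a functional assay on the whole organism (strain Wistar) for inhibition, with Rattus norvegicus as the target, read by paw edema, with stated times of 30 min and 3 h, at a dose of 0.05 mmol/kg by the oral route (on this read-out lower numbers stand for less inhibition and higher numbers for more inhibition at the one dose given (going by the name of the read-out)), compound 2 gives 26.6%. It stands level with compound 1 `CS(=O)(=O)c1ccc(N2N=C(c3ccccc3)CCC2=O)cc1`, which in this assay gives 26.6%: the step of no change at the digits printed from compound 1 to compound 2 (within the scatter) shows that putting in one chloro group left the read-out unchanged. Compound 3 `CS(=O)(=O)c1ccc(N2N=C(c3ccc(Cl)c(Cl)c3)CCC2=O)cc1` differs from compound 2 by chloro in place of hydrogen on an aromatic carbon. Going by the values given here, the one comparable step, no change at the digits printed from compound 1 to compound 2 (within the scatter), lay within the scatter, so no shift beyond the scatter is expected here either. The expected step is a number 0.4 percentage points higher from compound 2 to compound 3 (within the scatter). For compound 3 the estimate is 27%, with a range from 14% to 42%.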

Compound 3, a percentage reported as inhibition, in the whole organism at one dose (the size of the read-out at that dose, not a potency): 26.6%
Compound 3: the middle estimate sits 0.4 percentage points above what was measured; low and high end bracket the measured number.
By their numbers in this assay, from the lowest: compounds 1, 2 and 3 (each within the scatter of the next).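

In this assay, a second chloro group, ortho to the first, gives no change at the digits printed from compound 2 to compound 3 (within the scatter), so this ring position accepts a further chlorine without a shift beyond the scatter. Taken as a whole, 3,4-dichlorophenyl in place of phenyl gives no change at the digits printed from compound 1 to compound 3 (within the scatter), so even two chloro groups together leave the read-out where the bare phenyl had it. Nothing measured here speaks to why the read-out stays the same. Open, going by these compounds, is whether a group other than chloro on this ring, such as methoxy or an amine, would move the read-out.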